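Triazolyl for chloropyrazolyl on the acetamide arm

This account rests on a few compounds, and the source may have more. Where it says the series, first, only, none or still open, it means among the compounds named here.

The series keeps one core and varies the ring on the saturated chain carbon bound to a carbonyl carbon. Among the compounds with values here, compound 1 `C[C@@H]1CN(c2sc(C(F)(F)F)nc2-c2nc3ccccc3[nH]2)CCN1C(=O)Cn1cc(Cl)cn1` is measured in a functional assay on CHO-K1 cells for antagonist activity at C-X-C chemokine receptor type 3 (Homo sapiens), read by FLIPR, with a stated time of 10 min, in the presence of a further agent that is not named here (a lower number here means a stronger inhibitor, a higher number a weaker inhibitor), where compound 1 gives 1.7 nM, the lowest of the two numbers so far. Compound 2 `C[C@@H]1CN(c2sc(C(F)(F)F)nc2-c2nc3ccccc3[nH]2)CCN1C(=O)Cn1cnc2c1CCN(C)C2` carries a larger fused group at the same place and in this assay compound 2 gives 3.6 nM; the step of a 2.1-fold higher number from compound 1 to compound 2 (0.33 log units; beyond the scatter) shows that replacing the chloropyrazolyl ring there costs only a modest amount.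

Compound 3 `Cc1nc(C)n(CC(=O)N2CCN(c3sc(C(F)(F)F)nc3-c3nc4ccccc4[nH]3)C[C@H]2C)n1` is the next change at the same place: 3,5-dimethyl-1H-1,2,4-triazol-1-yl in place of 4-chloro-1H-pyrazol-1-yl on a saturated chain carbon bound to a carbonyl carbon. Within the data shown here, the only step that bears on it is the one from compound 1 to compound 2, which was modest and went toward a higher number. A smaller ring with one extra nitrogen and two methyl groups is expected to behave in the same direction and of similar size, so the estimated step is a 1.8-fold higher number from compound 1 to compound 3 (0.25 log units; within the scatter). In this assay compound 3 is therefore expected to give about 3 nM, with a range from 1.2 nM to 8 nM.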

Compound 3, half-maximal inhibitory concentration: 3.2 nM
For compound 3 the middle estimate is 1.1-fold (0.03 log units) below the measured one, and the stated range covers the measured number.
By their numbers in this assay, from the lowest: compounds 1, 3 and 2 (each within the scatter of the next, the first and the last beyond it).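

In this assay, a 1.9-fold higher number from compound 1 to compound 3 (0.27 log units; within the scatter), so at this place 3,5-dimethyl-1H-1,2,4-triazol-1-yl cannot be told apart from 4-chloro-1H-pyrazol-1-yl, and the chlorine is not required for a value in this range. With a 1.1-fold lower number from compound 2 to compound 3 (0.05 log units; within the scatter), compound 3 is not separated from the larger fused group either, and it sits within the scatter of both earlier compounds, even though the step between those two lies just beyond it. The three rings at this place therefore span a narrow range, and no measurement given here offers an explanation for these numbers.

The two methyl groups and the extra ring nitrogen enter together, so their separate contributions remain unresolved; the parent 1H-1,2,4-triazol-1-yl ring or a 3-methyl-1H-1,2,4-triazol-1-yl ring would be needed to divide them. All three groups also contain a five-membered aromatic ring with hetero atoms, which leaves open how far the tolerance extends to a different kind of group on the saturated chain carbon, such as an open-chain amine or a carboxylic acid.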